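Working Notes on the Step from Compound 2 to Compound 4

A few compounds are considered here, and "the series" means these few. Any claim that something is new, unique, unknown or untested is made for them only; others in the source may bear on it.

In an ADME assay on HepG2 cells (Homo sapiens) for inhibition, read by fluorescence and resazurin assay, with a stated time of 72 h (a higher number here means a weaker inhibitor, a lower number a stronger inhibitor), compound 1 `NS(=O)(=O)c1ccc(Nc2nccc(Nc3ccc4cn[nH]c4c3)n2)cc1` gives 22000 nM. Compound 3 `Cc1cc(Nc2nccc(Nc3ccc4nc[nH]c4c3)n2)ccc1N1CCN(C)CC1` gives 15000 nM in this assay. For compound 2 `CS(=O)(=O)Nc1cccc(Nc2nccc(Nc3ccc4nc[nH]c4c3)n2)c1` only a limit is known in this assay, namely > 25000 nM. Compound 2 thus stands at the limit of > 25000 nM in this assay, at which 1 of the 3 values shown sits, and no number places it against the other two. Compound 4 `CN1CCN(c2cccc(Nc3nccc(Nc4ccc5nc[nH]c5c4)n3)c2)CC1` is not yet measured; it differs from compound 2 by 4-methylpiperazin-1-yl in place of methanesulfonamido on an aromatic carbon. For the measured compounds named here, no step between measured compounds is known, so the expectation for this one rests on compound 3, which carries 4-methylpiperazin-1-yl and gives 15000 nM. The step of an at least 1.2-fold lower number from compound 2 to compound 4 (0.09 log units; that floor lies within the scatter) is expected to lie within the scatter or to bring a modest strengthening of inhibition. Compound 4 is estimated at 20000 nM, with a range from 8000 nM to 50000 nM.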

Compound 4, half-maximal inhibitory concentration: 11000 nM
Compound 4: middle estimate off by 1.8-fold (0.26 log units), on the high side, and the stated range covers the measured number.
By their numbers in this assay, from the lowest: compounds 4, 3 and 1 (each within the scatter of the next). At a limit, above all of these: compound 2.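

In this assay, for the compounds shown here, 4-methylpiperazin-1-yl in place of methanesulfonamido on this aromatic carbon gives an at least 2.2-fold lower number from compound 2 to compound 4 (0.35 log units; beyond the scatter), the only step that can be read so far, and it shows that this position responds to the change. The size of the step is only a floor, because compound 2 stands at a limit: the limit of > 25000 nM in this assay, at which 1 of the 4 values shown sits.

The compounds shown leave open how far the true step extends. They also leave open whether a morpholine ring or a dimethylamino group on this carbon would give a similar step.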